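Pyridin-3-yl for 3-fluorophenyl on the ring amine nitrogen

The source may report more compounds than this note shows. Statements on the series, on what has been measured and on what is new or still open speak of the compounds shown alone.

compound 1 `O=C(CN1CCN(c2ccc(F)cn2)CC1)Nc1nc2c(o1)CCCC2` — 100 nM
compound 2 `O=C(CN1CCN(c2cccc(F)c2)CC1)Nc1nc2c(s1)CCCC2` — > 1000 nM

In an assay on isolated protein for inhibition of long-chain fatty acid transport protein 1 (Homo sapiens), read by scintillation counting, with a stated time of 20 min (a higher number here means a weaker inhibitor, a lower number a stronger inhibitor), compound 1 gives 100 nM. Compound 2 stands at the limit of > 1000 nM in this assay, at which 1 of the 2 values shown sits, which is a limit of the assay and not a number. Compound 3 `O=C(CN1CCN(c2cccnc2)CC1)Nc1nc2c(s1)CCCC2` is not yet measured; it differs from compound 2 by pyridin-3-yl in place of 3-fluorophenyl on an amine nitrogen in a ring. For the measured compounds named here, no measured pair in the set isolates this change, and compound 1 differs from compound 2 in its core as well, so it does not settle the question. The step that the limit leaves unreadable from compound 2 to compound 3 is expected to be small, leaving compound 3 near the limit. Compound 3 is estimated at 1500 nM, within 400 nM to 5000 nM.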

Compound 3, half-maximal inhibitory concentration: > 1000 nM
Compound 3 ended at the assay's limit; the forecaster's own chance of this, stated with the estimate: 55%; the middle value lies beyond the limit too.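

For the compounds shown here, no step from compound 2 to compound 3 can be read in this assay, since both values are limits of the assay and not numbers: the limit of > 1000 nM in this assay, at which 2 of the 3 values shown sit. From the compounds shown here alone, whether pyridin-3-yl or 3-fluorophenyl on an amine nitrogen in a ring gives the stronger inhibitor stays open, as does the contribution of the core of compound 1.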